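This account rests on a few compounds, and the source may have more. Where it says the series, first, only, none or still open, it means among the compounds named here.

Compound 1 `CCn1c(Cc2ccccc2C(F)(F)F)nc(C(=O)NCc2ccccc2)c(O)c1=O`: > 100000 nM
Compound 2 `COc1c(C(=O)NCc2ccccc2)nc(Cc2ccccc2C(F)(F)F)n(C)c1=O`: > 100000 nM

In an ADME assay on HepG2 cells (Homo sapiens) for cytotoxicity, in the presence of a further agent that is not named here (on this read-out higher numbers stand for weaker inhibition and lower numbers for stronger inhibition), compound 2 gives > 100000 nM, which is a limit of the assay and not a number. Among the compounds with values here, compound 1 gives a limit too, and no measured compound has yet left it: the limit of > 100000 nM in this assay, at which 2 of the 2 values shown sit.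

Compound 3 `Cn1c(Cc2ccccc2C(F)(F)F)nc(C(=O)NCc2ccccc2)c(O)c1=O` differs from compound 2 in one place: hydrogen in place of methyl on an oxygen on an aromatic ring, or methoxy to hydroxy. Compound 1 already carries the hydroxy and still reads > 100000 nM, so little change is expected. The expected step, a number no higher from compound 2 to compound 3 (the limit leaves the size open), is estimated to stay within the scatter. For compound 3 the estimated value is 100000 nM, with an expected range from 50000 nM to 200000 nM.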

Compound 3, half-maximal inhibitory concentration: > 100000 nM
Compound 3: only a limit was reported; the forecaster's own chance of this, stated with the estimate: 85%; the middle value lies on the limit itself.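

Compound 3 is a limit of the assay and not a number, as are compound 1 and compound 2, so neither step to compound 3 can be read in this assay: the limit of > 100000 nM in this assay, at which 3 of the 3 values shown sit. The compounds shown leave open whether either one-place change alters the read-out at all.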